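Returning a Fluorinated Ring to the Amide Carbonyl

A few compounds are considered here, and "the series" means these few. Any claim that something is new, unique, unknown or untested is made for them only; others in the source may bear on it.

For the measured compounds named here, compound 3 `CC(C)[C@@H](NC(=O)CCCc1ccccc1)C(=O)N1CCC(c2ccc(Cl)cc2)CC1` gives 95 nM in an assay on THP-1 cells for displacement of a labelled ligand from C-C chemokine receptor type 1 (Homo sapiens) (a lower number here means a stronger inhibitor, a higher number a weaker inhibitor), the highest of the three numbers measured so far. Compound 2 `CC(C)C(NC(=O)c1ccc2ccccc2c1)C(=O)N1CCC(c2ccc(Cl)cc2)CC1` gives 80 nM, which lies within the scatter of compound 3, while compound 1 `CC(C)[C@@H](NC(=O)c1cccc(F)c1)C(=O)N1CCC(c2ccc(Cl)cc2)CC1` gives 24 nM, a clearly lower number. Compound 4 `CC(C)[C@@H](NC(=O)c1ccc(F)c(F)c1)C(=O)N1CCC(c2ccc(Cl)cc2)CC1` differs from compound 3 in a single place: 3,4-difluorophenyl in place of 3-phenylpropyl on a carbonyl carbon. Going by the values given here, one measured step bears directly on this change, and it runs the opposite way: a 4.0-fold higher number from compound 1 to compound 3 (0.60 log units; beyond the scatter). The change to compound 4 reverses that step, with a ring carrying two fluorines rather than one, so a lowering of the number of about the same size is expected, namely a 3.8-fold lower number from compound 3 to compound 4 (0.58 log units; beyond the scatter). Compound 4 is therefore estimated at 25 nM, within a range of 10 nM to 65 nM.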

Compound 4, half-maximal inhibitory concentration: 14 nM
The estimate for compound 4 lay 1.8-fold (0.25 log units) above the measured number; the range from low to high includes it.
By their numbers in this assay, from the lowest: compounds 4 and 1 (each within the scatter of the next); then compounds 2 and 3 (each within the scatter of the next).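

With a fluorinated ring on the carbonyl carbon, the lower number now appears twice, since 3,4-difluorophenyl in place of 3-phenylpropyl gives a 6.8-fold lower number from compound 3 to compound 4 (0.83 log units; beyond the scatter) in this assay. The second fluorine cannot be told apart from the first ring alone, as fluoro in place of hydrogen on an aromatic carbon gives a 1.7-fold lower number from compound 1 to compound 4 (0.23 log units; within the scatter), which stays within the scatter. No measurement here explains either step. Still open, going by these compounds, is how a phenyl ring with no fluorine on this carbonyl carbon would compare, and how a ring carrying chloro or nitrile in place of fluoro would compare.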